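The compounds below may be only part of what the source reports. "The series", "measured", "known", "first", "only" and "open" are said of these compounds alone.

In a functional assay on A2780 cells (Homo sapiens) for antiproliferative activity, read by MTT assay, with a stated time of 48 h (on this read-out lower numbers stand for stronger inhibition and higher numbers for weaker inhibition), compound 1 `COc1ccc(-c2cc3c(cn2)[nH]c(=O)n3-c2cc(OC)c(OC)c(OC)c2)cc1O` gives 240 nM, the lowest of the three numbers measured. Compound 2 `COc1ccc(-c2cc3c(cn2)[nH]c(=O)n3-c2cc(OC)c(OC)c(OC)c2)cn1` gives 990 nM, and compound 3 `CCOc1ccc(-c2cc3c(cn2)[nH]c(=O)n3-c2cc(OC)c(OC)c(OC)c2)cc1F` gives 4330 nM. Compound 4 `COc1ccc(-c2cc3c(cn2)n(C(C)C)c(=O)n3-c2cc(OC)c(OC)c(OC)c2)cc1O` differs from compound 1 in one place: isopropyl in place of hydrogen on an aromatic nitrogen. The measured steps, a 4.1-fold higher number from compound 1 to compound 2 (0.62 log units; beyond the scatter), an 18-fold higher number from compound 1 to compound 3 (1.26 log units; beyond the scatter) and a 4.4-fold higher number from compound 2 to compound 3 (0.64 log units; beyond the scatter), all change the group on an aromatic carbon. They range from modest to large, but none touches this nitrogen, so they give no direct guide. No step beyond the scatter is therefore firmly expected in this assay, and the expected change is a 1.5-fold higher number from compound 1 to compound 4 (0.16 log units; within the scatter). For compound 4 the estimated value is 350 nM, with an expected range of 60 nM to 2500 nM.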

Compound 4, half-maximal inhibitory concentration: 3160 nM
For compound 4 the middle estimate is 9.0-fold (0.96 log units) below the measured one; the whole stated range lies below it.
By their numbers in this assay, from the lowest: compound 1; then compound 2; then compounds 4 and 3 (each within the scatter of the next).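

In this assay, isopropyl in place of hydrogen on the aromatic nitrogen gives a 13-fold higher number from compound 1 to compound 4 (1.12 log units; beyond the scatter), a large step. This shows that the nitrogen, unchanged in compound 2 and compound 3, is itself a position where a substituent strongly alters the read-out, and that isopropyl is poorly tolerated there on the core of compound 1. No measurement here gives a reason for this step. Open, from the compounds shown here alone, is whether a methyl group, or a chain ending in an amine, would fare better on this nitrogen. Also open, going by these compounds, is whether isopropyl would produce a similar step with the aryl group of compound 2.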